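The compounds below may be only part of what the source reports. "The series", "measured", "known", "first", "only" and "open" are said of these compounds alone.

In a physicochemical assay for solubility, at pH 7.4 (on this read-out higher numbers stand for higher solubility and lower numbers for lower solubility), compound 1 `CCCCCCCc1cc(-c2ccc(CNC(=O)[C@H]3NCC[C@@H]3O)cc2)n[nH]1` gives 3.7 ug/mL. Compound 2 `CCCCCCc1nc(-c2ccc(CNC(=O)[C@H]3NCC[C@@H]3O)cc2)no1` gives > 50 ug/mL, which is a limit of the assay and not a number. Compound 3 `O=C(NCc1ccc(-c2noc(CCC3CC3)n2)cc1)[C@H]1NCC[C@@H]1O` keeps the shared core of compound 2 but carries cyclopropyl in place of butyl on a saturated chain carbon, two bonds along the chain from an aromatic carbon. Put another way, hexyl becomes 2-cyclopropylethyl. Going by the values given here, no measured pair shows this change, so the expected step that the limit leaves unreadable from compound 2 to compound 3 is none beyond the usual scatter. Compound 3 is estimated at 60 ug/mL, with an expected range from 20 ug/mL to 180 ug/mL.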

Compound 3, solubility: > 50 ug/mL
Compound 3: only a limit was reported; the forecaster's own chance of this, stated with the estimate: 65%; the middle value does not contradict the limit.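

In this assay, going by these compounds alone, compound 2 and compound 3 both give a limit of the assay and not a number, so no step between them can be read: the limit of > 50 ug/mL in this assay, at which 2 of the 3 values shown sit. Going by these compounds, how far the true solubility of each compound lies past that limit, and whether hexyl and 2-cyclopropylethyl differ at all, stays open.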